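A few compounds are considered here, and "the series" means these few. Any claim that something is new, unique, unknown or untested is made for them only; others in the source may bear on it.

Measured in a functional assay on MDA-MB-231 cells (Homo sapiens) for inhibition, read by sulforhodamine B assay; on this read-out lower numbers stand for stronger inhibition of growth and higher numbers for weaker inhibition of growth:
- compound 1 `Cc1ccc(CN2CCC=C(CCC(=O)NO)C2=O)cc1`: 1430 nM
- compound 2 `Cc1ccc(S(=O)(=O)Nc2ccc(CN3CCC=C(CCC(=O)NO)C3=O)cc2)cc1`: 560 nM

Of the two measured compounds, compound 2 stands lowest in this assay, at 560 nM. Its nearest neighbour is compound 1, with the higher number of 1430 nM, and the gap between them lies beyond the usual scatter. Compound 2 is therefore the stronger growth inhibitor of this pair.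

The next compound, compound 3 `O=C(CCC1=CCCN(Cc2ccc(NC(=O)c3ccccc3)cc2)C1=O)NO`, has not yet been measured. It carries benzoyl in place of (4-methylphenyl)sulfonyl on a nitrogen on an aromatic ring. The rest of the structure stays the same.

For the measured compounds named here, no measured pair shows what this exchange does, so the expectation rests on little. In this assay, no step beyond the scatter is expected, and a move in either direction remains possible. The expected change is a 1.1-fold lower number from compound 2 to compound 3 (0.03 log units; within the scatter). For compound 3 the estimated value is 520 nM, with an expected range from 220 nM to 1250 nM.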

Compound 3, concentration for 50% growth inhibition: 6030 nM
Compound 3: middle estimate off by 12-fold (1.06 log units), on the low side; the measured number lies above the stated range.
By their numbers in this assay, from the lowest: compound 2; then compound 1; then compound 3.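

In this assay, the group on the nitrogen on the aromatic ring turns out to matter a great deal: benzoyl in place of (4-methylphenyl)sulfonyl gives an 11-fold higher number from compound 2 to compound 3 (1.03 log units; beyond the scatter) and so reverses the expectation of little change. Benzamido in place of methyl on an aromatic carbon also fails to strengthen growth inhibition, giving a 4.2-fold higher number from compound 1 to compound 3 (0.62 log units; beyond the scatter) with the rest of the structure unchanged, so the extended substituent does not help in its benzoyl form. As both the leaving and the entering group hold one six-membered aromatic ring of carbon only, that ring alone does not keep the number low, and nothing available on these compounds explains the difference.

As far as these compounds go, it remains open whether the low number of compound 2 is specific to (4-methylphenyl)sulfonyl or would also appear with a smaller methanesulfonyl group or a plain phenylsulfonyl group on the same nitrogen. From the compounds shown here alone, it is equally open whether the large step is particular to benzoyl or would extend to an acetyl group, a urea or a free amine at that place.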